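The source may report more compounds than this note shows. Statements on the series, on what has been measured and on what is new or still open speak of the compounds shown alone.

Of the compounds shown here, three sharing one core have been measured in a functional assay (B cells) with Mus musculus as the target; a lower number here means that less compound is needed, a higher number that more compound is needed for the effect. Compound 1 `C=CCn1c(=O)n(CCC(CCOCc2ccccc2)CCOCc2ccccc2)c2nc(N)nc(O)c21` gives 7 uM in this assay. Compound 3 `C=CCn1c(=[Se])n(C2OC(CO)[C@@H](O)[C@H]2O)c2nc(N)nc(O)c21` gives 15 uM. Compound 2 `Nc1nc(O)c2c(n1)n(C1OC(CO)[C@@H](O)[C@H]1O)c(=O)n2CC(O)CSc1ccccc1` gives 142 uM, the highest of the three numbers, so it needs the most compound for the same effect; its nearest neighbour is compound 3, the gap to compound 1 is wider still, and both gaps lie beyond the usual scatter of repeated measurements.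

Compound 4 `Nc1nc(O)c2c(n1)n(C1OC(CO)[C@@H](O)[C@H]1O)c(=O)n2Cc1ccc([N+](=O)[O-])cc1` has not yet been measured. It is built from compound 2 by one change: 4-nitrophenyl in place of 1-hydroxy-2-(phenylsulfanyl)ethyl on a saturated chain carbon bound to an aromatic nitrogen. For the measured compounds named here, no pair of measured compounds differs in just this way, so nothing in the measured set tells directly how large a step this change brings.

The expectation must therefore rest on where compound 2 sits. Since compound 2 gives the highest of the three numbers with 142 uM, and the other two members of the series sit well below it, a move towards those values seems more likely than a move further away. For compound 4 the expected step is a 2.4-fold lower number from compound 2 to compound 4 (0.37 log units; beyond the scatter), a lowering of the number, though it may also prove to be none beyond the scatter. The estimate for compound 4 in this assay is 60 uM, with a range from 15 uM to 250 uM.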

Compound 4, concentration for half-maximal effect: 40 uM
Compound 4: middle estimate off by 1.5-fold (0.18 log units), on the high side, within the range that was stated.
By their numbers in this assay, from the lowest: compound 1; then compound 3; then compound 4; then compound 2.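

For the compounds shown here, on a saturated chain carbon bound to an aromatic nitrogen, putting 4-nitrophenyl in place of 1-hydroxy-2-(phenylsulfanyl)ethyl gives a 3.6-fold lower number from compound 2 to compound 4 (0.55 log units; beyond the scatter) in this assay and so provides the only single-change step, a modest one but beyond the scatter. This shows that the number responds to what sits at this position, even though the leaving and entering groups each hold one six-membered aromatic ring of carbon only and the same count of hydrogen-bond acceptors, while the leaving group's sulfur and hydrogen-bond donor are lost and nitrogen enters. Which of these differences matters cannot be told from one pair, and no measurement at hand explains the step.

Going by these compounds alone, with only this pair, it remains open whether a plain phenyl, an amine or a carboxylic acid in place of the nitro group would give a similar number. Also open, from the compounds shown here alone, is whether the same exchange would bring a step of similar size in compounds carrying the other groups seen elsewhere, such as the allyl group of compound 1 and compound 3.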